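A few compounds are considered here, and "the series" means these few. Any claim that something is new, unique, unknown or untested is made for them only; others in the source may bear on it.

Series of three measured compounds on one shared core: compound 1 `c1ccc(COc2cccc(-c3cn([C@H]4CN5CCC4CC5)nn3)c2)cc1`, compound 2 `FCCCOc1cccc(-c2cn([C@H]3CN4CCC3CC4)nn2)c1` and compound 3 `Fc1ccc(COc2cccc(-c3cn([C@H]4CN5CCC4CC5)nn3)c2)cc1`. In an assay on HEK293 cells for displacement of a labelled ligand from Neuronal acetylcholine receptor; alpha4/beta2 (Homo sapiens), read by scintillation counting, with a stated time of 120 min (a lower number here means a stronger inhibitor, a higher number a weaker inhibitor), compound 1 gives 5060 nM, compound 2 gives 9010 nM and compound 3 gives 6390 nM. Compound 2 holds the highest number of the three, with compound 3 nearest and compound 1 furthest; the corresponding steps are a 1.4-fold lower number from compound 2 to compound 3 (0.15 log units; within the scatter) and a 1.8-fold higher number from compound 1 to compound 2 (0.25 log units; within the scatter), both within the scatter, and the remaining step of a 1.3-fold higher number from compound 1 to compound 3 (0.10 log units; within the scatter) is within the scatter as well, so no order among the three is claimed.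

Compound 4 `FCCCOc1cccc(-c2cn(C3CN4CCC3CC4)nn2)c1` is next to be measured in this assay. Its relation to compound 2: the two compounds have the same atoms and bonds; at least one stereo element is drawn with a configuration in one of them and without one in the other: 1 of 3 stereo elements differ; a stereocentre at a saturated ring carbon is drawn R in compound 2 and without a configuration in compound 4. Every measured step changes the group on the saturated chain carbon bound to an oxygen on an aromatic ring, and none touches a stereo element, so none of them bears directly on this change. The set offers no stereo comparison at all. The expectation therefore rests on compound 2 and its value of 9010 nM. The step expected for compound 4 is a 1.4-fold higher number from compound 2 to compound 4 (0.16 log units; within the scatter), near the edge of the scatter and, if anything, toward a higher number. Compound 4 is estimated at 13000 nM, with a range from 5500 nM to 32000 nM.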

Compound 4, inhibition constant: 3890 nM
Compound 4: middle estimate off by 3.3-fold (0.52 log units), on the high side; the whole stated range lies above it.
By their numbers in this assay, from the lowest: compounds 4, 1, 3 and 2 (each within the scatter of the next, the first and the last beyond it).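

In this assay, among the compounds shown here, the first step to pass beyond the scatter is a 2.3-fold lower number from compound 2 to compound 4 (0.36 log units; beyond the scatter), whereas the three earlier steps, all changing the group on the saturated chain carbon bound to an oxygen on an aromatic ring, stay within it. A change at the stereocentre on the saturated ring carbon, with atoms and bonds unchanged, therefore registers in this assay where no group exchange shown does, although the step is only modest, and with the 2-fluoroethyl group the lower number belongs to the compound drawn without a configuration, not to the one drawn R. The step can be tied to one structural feature alone, the difference in stereo drawing: the fact that one of compounds 2 and 4 is drawn with a defined configuration and the other without, at the place where they differ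

As far as these compounds go, the composition of compound 4 at this stereocentre stays open, so the number for the opposite drawn configuration cannot be inferred, nor can it be said whether a step of this kind recurs with phenyl or 4-fluorophenyl in place of 2-fluoroethyl. Also open, from the compounds shown here alone, is how a hydroxyl group, an amine or a longer chain in place of the 2-fluoroethyl group would read on either stereo drawing.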